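Lengthening the Side Chain of Compound 3

This account rests on a few compounds, and the source may have more. Where it says the series, first, only, none or still open, it means among the compounds named here.

The compounds share one core and differ only in the chain attached to an oxygen on an aromatic ring. Compound 2 `CCOC(=O)CCCCOc1ccc2c(=O)c(-c3ccc(O)cc3)coc2c1` carries a short chain ending in an ethyl ester, and in an assay (Cricetulus griseus) for inhibition of aldehyde dehydrogenase, mitochondrial (Homo sapiens) (on this read-out higher numbers stand for weaker inhibition and lower numbers for stronger inhibition), compound 2 gives 240 nM. Compound 3 `NCCCCOc1ccc2c(=O)c(-c3ccc(O)cc3)coc2c1` carries a chain of the same length ending in an amine, and in this assay compound 3 gives 250 nM. The step of a 1.0-fold higher number from compound 2 to compound 3 (0.02 log units; within the scatter) shows that swapping these end groups changes nothing beyond the scatter. Compound 1 `O=C(O)CCCCCCCCCCCCCCCOc1ccc2c(=O)c(-c3ccc(O)cc3)coc2c1` carries a much longer chain ending in a carboxylic acid. For compound 1 the result in this assay is only a limit, > 9000 nM. Of the two real numbers, compound 3 has the higher one, but its distance to compound 2 is within the scatter.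

Compound 4 `O=C(O)CCCCCCCCCCCOc1ccc2c(=O)c(-c3ccc(O)cc3)coc2c1` comes next. The change from compound 3 is 7-carboxyheptyl in place of amino on a saturated chain carbon, four bonds along the chain from an oxygen on an aromatic ring. Within the data shown here, no measured step covers this change directly. The step of a 1.0-fold higher number from compound 2 to compound 3 (0.02 log units; within the scatter) says the amine can be exchanged without cost; what is new is the length of the chain and the acid at its end. Compound 1, with a still longer acid chain, reaches only the limit (the limit of > 9000 nM in this assay, at which 1 of the 3 values shown sits), which points toward weaker inhibition as the chain grows. The estimate for compound 4 in this assay is therefore 2000 nM, between 500 nM and 9000 nM, an expected step of an 8.0-fold higher number from compound 3 to compound 4 (0.90 log units; beyond the scatter) toward weaker inhibition.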

Compound 4, half-maximal inhibitory concentration: 130 nM
The estimate for compound 4 lay 15-fold (1.19 log units) above the measured number; measured number outside the range, below it.
By their numbers in this assay, from the lowest: compounds 4, 2 and 3 (each within the scatter of the next). At a limit, above all of these: compound 1.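

In this assay, the chain carbon four bonds along the chain from an oxygen on an aromatic ring accepts 7-carboxyheptyl with a 1.9-fold lower number from compound 3 to compound 4 (0.28 log units; within the scatter) and a 1.8-fold lower number from compound 2 to compound 4 (0.27 log units; within the scatter), so a much longer chain ending in a carboxylic acid is as well accepted here as the short chains ending in an amine or an ethyl ester. Length and an acid end do not by themselves weaken inhibition in compound 4, and the real break appears only with the still longer acid chain, where carboxy in place of 4-carboxybutyl gives an at least 69-fold lower number from compound 1 to compound 4 (1.84 log units; beyond the scatter). The result for compound 1 is a limit and not a number: the limit of > 9000 nM in this assay, at which 1 of the 4 values shown sits.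

Only two lengths of acid chain are shown, so an acid chain of intermediate length would be needed to locate where inhibition starts to fall away. A short chain ending in a carboxylic acid, or the longest chain ending in an amine or an ethyl ester, would show whether the end group matters at each length or the chain length alone sets the result.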